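Bromo in place of methyl on the aryl ring

This account rests on a few compounds, and the source may have more. Where it says the series, first, only, none or still open, it means among the compounds named here.

Within the data shown here, in an ADME assay on HEK293 cells (Homo sapiens) for antiproliferative activity, read by MTT assay (on this read-out higher numbers stand for weaker inhibition and lower numbers for stronger inhibition), compound 2 `Cc1ccc(/C=N/NC(=O)c2oc3nc(-c4ccccc4)cc(C(F)(F)F)c3c2N)cc1` gives 69000 nM and stands with the lower of the two numbers measured so far, though its distance from compound 1 is within the scatter. In this assay compound 1 `CCNC(=O)c1oc2nc(-c3ccccc3)cc(C(F)(F)F)c2c1N` gives 70000 nM. Compound 3 `Nc1c(C(=O)N/N=C/c2ccc(Br)cc2)oc2nc(-c3ccccc3)cc(C(F)(F)F)c12` differs from compound 2 by bromo in place of methyl on an aromatic carbon. Among the measured compounds shown here, the only measured step, a 1.0-fold lower number from compound 1 to compound 2 (0.01 log units; within the scatter), concerns the amide-type nitrogen and not the aromatic ring changed here, so no step on the same ground exists. Both measured numbers being alike, no change beyond the scatter is expected. Compound 3 is therefore estimated at 65000 nM with a range of 30000 nM to 150000 nM. The expected step is a 1.1-fold lower number from compound 2 to compound 3 (0.03 log units; within the scatter).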

Compound 3, half-maximal inhibitory concentration: 64000 nM
Beside the measured number, compound 3's estimate is 1.0-fold (0.01 log units) above it, within the range that was stated.
By their numbers in this assay, from the lowest: compounds 3, 2 and 1 (each within the scatter of the next).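

In this assay, going from 4-methylphenyl to 4-bromophenyl gives a 1.1-fold lower number from compound 2 to compound 3 (0.03 log units; within the scatter), so this first change on the aromatic ring, para to a large group, leaves the read-out within the scatter. Against the short group on the amide-type nitrogen, the bromo-bearing group gives a 1.1-fold lower number from compound 1 to compound 3 (0.04 log units; within the scatter), and so, like the methyl-bearing group, it is not separated from compound 1. No evidence bears on this flat result. From the compounds shown here alone, whether an amine or a carboxylic acid at this ring position would move the number beyond the scatter stays open.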